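The compounds below may be only part of what the source reports. "The series", "measured", "known", "first", "only" and "open" are said of these compounds alone.

In an ADME assay on L929 cells (Mus musculus) for cytotoxicity, read by resazurin assay, with a stated time of 48 h (a lower number here means that less compound is tolerated, a higher number that more compound is tolerated), compound 3 (`CNC(=O)CCCn1c2ccc([N+](=O)[O-])cc2c(=O)n1Cc1ccccc1`) reads > 256000 nM and this is a limit, not a number. Compound 1 (`N#CCn1c2ccc([N+](=O)[O-])cc2c(=O)n1Cc1ccccc1`) reads > 256000 nM and this is also a limit. Compound 2 (`COC(=O)CCn1c2ccc([N+](=O)[O-])cc2c(=O)n1Cc1ccccc1`) reads > 256000 nM and this is again a limit. Among the compounds with values here, compound 3 therefore stands level with the other two, as the limit of > 256000 nM in this assay, at which 3 of the 3 values shown sit, shows for the series so far.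

Compound 4 (`COCCn1c2ccc([N+](=O)[O-])cc2c(=O)n1Cc1ccccc1`) carries methoxy in place of (methylcarbamoyl)methyl on a saturated chain carbon, two bonds along the chain from an aromatic nitrogen. Within the data shown here, three measured steps bear on this change: a step that the two limits leave unreadable from compound 1 to compound 2 along with a step that the two limits leave unreadable from compound 1 to compound 3 along with a step that the two limits leave unreadable from compound 2 to compound 3 give no size to carry over, though none of them shows a number falling out from the limit. The expected size of a number no higher from compound 3 to compound 4 (the limit leaves the size open) stays within the scatter, with no direction expected in this assay at all. Compound 4 is estimated at 256000 nM with an expected range of 128000 nM to 512000 nM and a reading at the limit is the likeliest outcome.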

Compound 4, concentration lethal to 50% of the cells: > 256000 nM
Compound 4: no number, only a limit; the forecaster's own chance of this, stated with the estimate: 85%; the middle value lies on the limit itself.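

In this assay compound 4 joins compounds 1, 2 and 3 as a limit, so no step among these four compounds can be read: the limit of > 256000 nM in this assay, at which 4 of the 4 values shown sit.

The compounds shown leave open how far the side chains on the shared core differ in this assay, since none gives a number.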